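The source may report more compounds than this note shows. Statements on the series, on what has been measured and on what is new or still open speak of the compounds shown alone.

Measured compounds:
Compound 1 `CCOC(=O)N1CCN(CCCOc2ccc(-c3c[nH]cn3)cc2)CC1` gives 69200 nM in an assay on isolated protein for binding affinity to histamine H2 receptor (Homo sapiens); a higher number here means a weaker inhibitor, a lower number a stronger inhibitor.
Compound 2 `CCOC(=O)N1CCN(CCCOc2ccc(-c3cccs3)cc2)CC1` gives 33100 nM in this assay.
Compound 3 `CCOC(=O)N1CCN(CCCOc2ccc(-c3ccc(OC)cc3)cc2)CC1` gives 100000 nM in this assay.

Compound 3 has the highest number of the three. Its nearest neighbour is compound 1, and that gap, a 1.4-fold higher number from compound 1 to compound 3 (0.16 log units; within the scatter), lies within the scatter, so no order between the two can be claimed. The furthest is compound 2, where a 3.0-fold higher number from compound 2 to compound 3 (0.48 log units; beyond the scatter) lies beyond the scatter; likewise a 2.1-fold lower number from compound 1 to compound 2 (0.32 log units; beyond the scatter) lies beyond it.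

Compound 4 `CCOC(=O)N1CCN(CCCOc2ccc(-c3ccncc3)cc2)CC1` is not yet measured. It differs from compound 3 by pyridin-4-yl in place of 4-methoxyphenyl on an aromatic carbon. The two steps that bear on it are those into compound 3: a five-membered aromatic group exchanged for the 4-methoxyphenyl moved the number only within the scatter in one case and modestly beyond it in the other. Exchanging one aromatic group for another at this position has therefore given small to modest shifts, and the change to pyridin-4-yl, a six-membered aromatic ring with one hetero atom, is expected to stay in that range, if anything toward a lower number, as compound 1 shows a slightly lower value than compound 3 in this assay.

Compound 4 is thus estimated at 60000 nM, within 25000 nM to 150000 nM, which is an expected step of a 1.7-fold lower number from compound 3 to compound 4 (0.22 log units; within the scatter).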

Compound 4, inhibition constant: 57500 nM
The estimate for compound 4 lay 1.0-fold (0.02 log units) above the measured number; the range from low to high includes it.
By their numbers in this assay, from the lowest: compounds 2, 4, 1 and 3 (each within the scatter of the next, the first and the last beyond it).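

At this position, para to a large group, pyridin-4-yl cannot be separated in this assay from any of the three other groups: the comparisons with 4-methoxyphenyl (a 1.7-fold lower number from compound 3 to compound 4 (0.24 log units; within the scatter)), thiophen-2-yl (a 1.7-fold higher number from compound 2 to compound 4 (0.24 log units; within the scatter)) and 1H-imidazol-4-yl (a 1.2-fold lower number from compound 1 to compound 4 (0.08 log units; within the scatter)) all stay within the scatter. The six-membered aromatic ring with one hetero atom therefore gives no readable change from the six-membered aromatic ring of carbon only carried by 4-methoxyphenyl, and compound 4 sits inside the span from compound 2 (33100 nM) to compound 3 (100000 nM), while the separation of compound 2 from compound 1 and from compound 3 stands as before. No measurement at hand accounts for this flat result.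

Going by these compounds, the four compounds cover only aromatic rings attached directly at this position, so it remains open whether a primary amine, a carboxylic acid or an open alkyl chain there would leave the number in this span. The series also leaves open how pyridin-3-yl or pyridin-2-yl would compare with pyridin-4-yl, and whether a longer chain in the shared core would shift all of these values.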